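Exchanging the ethylamide for a morpholine amide

The source may hold more compounds than are shown below. What is called first, only, known or untested is meant among the compounds shown, and "the series" means these compounds.

Compound 1 `O=C(CCc1ccc(Cl)cc1)C(=O)NCCCCc1ccccc1` — 1580 nM
Compound 2 `CCOC(=O)C(F)(F)C(O)CCc1ccccc1` — > 10000 nM
Compound 3 `CCNC(=O)C(=O)CCc1ccc(Cl)cc1` — 3980 nM

In an assay on HEK-293T cells for inhibition of phospholipase A and acyltransferase 4 (Homo sapiens), with stated times of 30 min and 20 min (on this read-out higher numbers stand for weaker inhibition and lower numbers for stronger inhibition), compound 1 gives 1580 nM. In this assay compound 3 gives 3980 nM, the highest of the two numbers shown. For compound 2 this assay reports only a limit, > 10000 nM, and not a number (the limit of > 10000 nM in this assay, at which 1 of the 3 values shown sits).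

Among the measured compounds shown here, the one step with numbers on both sides, a 2.5-fold higher number from compound 1 to compound 3 (0.40 log units; beyond the scatter), runs in the direction of a weaker inhibition when the chain on the amide nitrogen is shortened.

Compound 4 `O=C(CCc1ccc(Cl)cc1)C(=O)N1CCOCC1` differs from compound 3 by morpholin-4-yl in place of ethylamino on a carbonyl carbon. For the measured compounds named here, no measured pair shares this change; the step from compound 1 to compound 3 touches the same nitrogen but alters only the length of a chain, not the amide hydrogen or ring closure, so it bears on the change only loosely. Without a closer precedent, compound 4 is expected to stay near compound 3, with a wide margin on either side. The estimate for compound 4 in this assay is 5000 nM, in the range 1500 nM to 16000 nM. That estimate means a step of a 1.3-fold higher number from compound 3 to compound 4 (0.10 log units; within the scatter), which is expected to lie within the scatter of repeated measurements.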

Compound 4, half-maximal inhibitory concentration: > 10000 nM
Compound 4: no number, only a limit (the forecaster's own chance of this, stated with the estimate: 25%); at least 2.0-fold (0.30 log units) between middle value and limit.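

Exchanging ethylamino for morpholin-4-yl on a carbonyl carbon is the first change shown that closes the amide nitrogen into a ring and takes away the amide hydrogen, and it gives an at least 2.5-fold higher number from compound 3 to compound 4 (0.40 log units; beyond the scatter) for this exchange. In this assay compound 4 gives > 10000 nM as a limit of the assay and not a number. Together with a 2.5-fold higher number from compound 1 to compound 3 (0.40 log units; beyond the scatter) as the earlier step, this means that both changes shown on this amide nitrogen run towards weaker inhibition, so neither the shorter chain nor the morpholine ring improves on compound 1 among these compounds.

The compounds shown do not separate the loss of the amide hydrogen from the closing of the ring or from the ring oxygen, which a dimethylamino group or a piperidin-1-yl group in the same place would pull apart. As far as these compounds go, how large the step to compound 4 really is also stays open, because compound 4 sits at the limit of the assay and gives no number to measure it against: the limit of > 10000 nM in this assay, at which 2 of the 4 values shown sit.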